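Swapping the aryl group on the hydrazone end

The source may hold more compounds than are shown below. What is called first, only, known or untested is meant among the compounds shown, and "the series" means these compounds.

Measured compounds:
compound 1 `COc1ccc(/C=N/NC(=O)Nc2ccc(Oc3ccnc(-c4nncn4CCN(C)C)c3)c(F)c2)c(OC)c1OC` with 6680 nM
compound 2 `CN(C)CCn1cnnc1-c1cc(Oc2ccc(NC(=O)N/N=C/c3ccc(O)c(F)c3)cc2F)ccn1` with 13400 nM

Among the compounds with values here, in a functional assay on A549 cells (Homo sapiens) for cytotoxicity, read by MTT assay, with a stated time of 72 h (a lower number here means a stronger inhibitor, a higher number a weaker inhibitor), compound 2 gives the highest of the two numbers measured so far, while compound 1 gives a lower number; the step of a 2.0-fold higher number from compound 1 to compound 2 (0.30 log units; within the scatter) is within the scatter, so the two cannot be ranked. Compound 3 `COc1ccc(/C=N/NC(=O)Nc2ccc(Oc3ccnc(-c4nncn4CCN(C)C)c3)c(F)c2)cc1O` is not yet measured. It differs from compound 2 by a single change: 3-hydroxy-4-methoxyphenyl in place of 3-fluoro-4-hydroxyphenyl on a carbon with a double bond to nitrogen. Within the data shown here, the only measured step that bears on this position, a 2.0-fold higher number from compound 1 to compound 2 (0.30 log units; within the scatter), exchanged a methoxy-bearing aryl group for a fluoro-hydroxy one without moving beyond the scatter. Compound 3 carries both a hydroxy and a methoxy group on that ring, so the change from compound 2 is expected to produce no step beyond the scatter in this assay, with the expected step being a 1.4-fold lower number from compound 2 to compound 3 (0.15 log units; within the scatter). For compound 3 the estimated value is 9500 nM, expected to lie between 3500 nM and 26000 nM.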

Compound 3, half-maximal inhibitory concentration: > 100000 nM
Compound 3: no number, only a limit; the forecaster's own chance of this, stated with the estimate: 5%; middle value at least 10-fold (1.02 log units) from the limit.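

The aryl group on the carbon with a double bond to nitrogen can matter a great deal in this assay: placing 3-hydroxy-4-methoxyphenyl there gives an at least 7.4-fold higher number from compound 2 to compound 3 (0.87 log units; beyond the scatter), and measured against 2,3,4-trimethoxyphenyl it gives an at least 14-fold higher number from compound 1 to compound 3 (1.17 log units; beyond the scatter). The reading for compound 3 is a limit of the assay, not a number: the limit of > 100000 nM in this assay, at which 1 of the 3 values shown sits. The earlier exchange stayed within the scatter and suggested a forgiving site, but these steps show that not every aryl group is tolerated there.

The step from 3-fluoro-4-hydroxyphenyl removes the fluorine, adds a methoxy group and alters the hydroxy pattern all at once, so the compounds shown cannot say which of these changes counts. They also leave open how an amine or a carboxylic acid on this ring would read in this assay.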